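Swapping a Halogen on the Sulfonyl Aryl Ring

The source may hold more compounds than are shown below. What is called first, only, known or untested is meant among the compounds shown, and "the series" means these compounds.

Measured so far:
- compound 1 `Cc1ccc(S(=O)(=O)c2nc3ccccc3nc2Nc2cccc(N)c2)cc1`: 2000 nM
- compound 2 `Nc1cccc(Nc2nc3ccccc3nc2S(=O)(=O)c2ccc(Br)cc2)c1`: 9010 nM
- compound 3 `O=S(=O)(c1ccc(Br)cc1)c1nc2ccccc2nc1Nc1ccc(Cl)cc1`: 7460 nM

Of the compounds shown here, three sharing one core have been tested in a functional assay on PC-3 cells (Homo sapiens) for cytotoxicity, read by MTT assay, with a stated time of 72 h; on this read-out higher numbers stand for weaker inhibition and lower numbers for stronger inhibition. Compound 1 gives 2000 nM, compound 2 gives 9010 nM and compound 3 gives 7460 nM. Among these, compound 2 carries the highest number of the three; its nearest neighbour is compound 3, whose value lies within the scatter of it, while compound 1 sits furthest away, with a 4.5-fold higher number from compound 1 to compound 2 (0.65 log units; beyond the scatter). Compound 3 differs from compound 2 only in the group on the ring nitrogen, and a 1.2-fold lower number from compound 2 to compound 3 (0.08 log units; within the scatter).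

The next compound, compound 4 `Nc1cccc(Nc2nc3ccccc3nc2S(=O)(=O)c2ccc(F)cc2)c1`, is not yet measured. It differs from compound 2 in one place: fluoro in place of bromo on an aromatic carbon, on an aromatic carbon of a six-membered aromatic ring of carbon only, para to a large group. Within the data shown here, the one measured step that touches this same carbon is the one from compound 1 to compound 2, where a bromo replaced a methyl and the number rose modestly. Among the measured compounds shown here, no measured step goes from bromo to fluoro, so the direction is uncertain. A modest move back toward the value of compound 1 seems the most plausible expectation, with a wide range. Compound 4 is therefore expected to give about 5000 nM, between 2000 nM and 12500 nM, which would mean a 1.8-fold lower number from compound 2 to compound 4 (0.26 log units; within the scatter) as an estimated step.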

Compound 4, half-maximal inhibitory concentration: 1980 nM
Compound 4: middle estimate off by 2.5-fold (0.40 log units), on the high side; the measured number lies below the stated range.
By their numbers in this assay, from the lowest: compounds 4 and 1 (each within the scatter of the next); then compounds 3 and 2 (each within the scatter of the next).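

In this assay the new step shows that the identity of a single atom at this carbon, para to a large group, matters: with 3-aminophenyl kept on the nitrogen, the change gives a 4.6-fold lower number from compound 2 to compound 4 (0.66 log units; beyond the scatter), even though one heavy atom replaces one heavy atom and the counted hydrogen-bond donors, acceptors and net charge stay the same. Fluoro and methyl cannot be told apart at this carbon, with a 1.0-fold lower number from compound 1 to compound 4 (0.00 log units; within the scatter), so among the three groups seen here bromo alone stands apart from the others, and it carries the higher number. No measurement of any property of these groups is available to explain this difference.

As far as these compounds go, it remains open whether chloro, iodo, methoxy or an amine at this carbon would group with bromo or with fluoro and methyl. Among these compounds, it is also open whether replacing bromo with fluoro would produce a similar step when 4-chlorophenyl rather than 3-aminophenyl sits on the nitrogen, since the one step seen here has 3-aminophenyl in that place.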